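Replacing 4-bromophenyl with phenethyl on the sulfur chain

This account rests on a few compounds, and the source may have more. Where it says the series, first, only, none or still open, it means among the compounds named here.

Three close relatives share one core and differ only in the group on a saturated chain carbon bound to a sulfur. Compound 1 `Cc1cc(N2CC[C@@H](C)[C@@H](N(C)c3ncnc4[nH]ccc34)C2)n2nc(SCC3CC3)nc2n1` carries a cyclopropyl there, and in a toxicity assay on GES1 cells (Homo sapiens) for inhibition, read by MTT assay, with a stated time of 72 h (a higher number here means a weaker inhibitor, a lower number a stronger inhibitor), compound 1 gives 27900 nM. Compound 2 `Cc1cc(N2CC[C@@H](C)[C@@H](N(C)c3ncnc4[nH]ccc34)C2)n2nc(SCc3ccccc3Br)nc2n1` gives in this assay only a limit, > 100000 nM. Compound 3 `Cc1cc(N2CC[C@@H](C)[C@@H](N(C)c3ncnc4[nH]ccc34)C2)n2nc(SCc3ccc(Br)cc3)nc2n1` gives 55600 nM in this assay, the highest of the two numbers shown, though a 2.0-fold higher number from compound 1 to compound 3 (0.30 log units; within the scatter), so the two cannot be told apart. The one clear move is an at least 3.5-fold higher number from compound 1 to compound 2 (0.55 log units; beyond the scatter), while an at least 1.7-fold lower number from compound 2 to compound 3 (0.25 log units; that floor lies within the scatter).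

Compound 4 `Cc1cc(N2CC[C@@H](C)[C@@H](N(C)c3ncnc4[nH]ccc34)C2)n2nc(SCCCc3ccccc3)nc2n1` has not yet been measured in this assay. It differs from compound 3 in one place: phenethyl in place of 4-bromophenyl on a saturated chain carbon bound to a sulfur. Among the compounds with values here, the steps that speak to this swap are the exchanges at the same position, of which a 2.0-fold higher number from compound 1 to compound 3 (0.30 log units; within the scatter) and an at least 1.7-fold lower number from compound 2 to compound 3 (0.25 log units; that floor lies within the scatter) both stayed within the scatter, and only the step to compound 2 went beyond it. A ring without bromine, moved one carbon further from the sulfur, is therefore expected to leave the number about where compound 3 sits: the expected step is a 1.1-fold lower number from compound 3 to compound 4 (0.05 log units; within the scatter). Compound 4 is estimated at 50000 nM, with a range from 20000 nM to 100000 nM.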

Compound 4, half-maximal inhibitory concentration: > 100000 nM
Compound 4 gave a limit, no number (the forecaster's own chance of this, stated with the estimate: 25%); middle value at least 2.0-fold (0.30 log units) from the limit.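

In this assay, a second clear separation from the cyclopropyl of compound 1 now appears, an at least 3.5-fold higher number from compound 1 to compound 4 (0.55 log units; beyond the scatter), so a shift of this size at this position does not require a bromine on the ring. Compound 3, with its 4-bromophenyl, goes against any rule that an aromatic ring on the sulfur chain is enough to produce such a shift, yet its comparison with the new compound gives only a floor: an at least 1.7-fold higher number from compound 3 to compound 4 (0.25 log units; that floor lies within the scatter). Compound 4 gives only a limit, as compound 2 does, so the step between those two cannot be read: the limit of > 100000 nM in this assay, at which 2 of the 4 values shown sit.

From the compounds shown here alone, the true values of compound 2 and compound 4 remain unknown, and so does whether compound 4 really differs from compound 3, since the floor of that step lies within the scatter. The compounds shown also leave open how an amine or a carboxylic acid in place of the ring would change the number, and whether a plain benzyl group, with no bromine and the shorter chain, would sit closer to compound 3 or to compound 4.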